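This account rests on a few compounds, and the source may have more. Where it says the series, first, only, none or still open, it means among the compounds named here.

Working notes on the series. In an ADME assay on J774.A1 cells (Mus musculus) for cytotoxicity, read by MTT assay, with a stated time of 48 h (on this read-out lower numbers stand for higher toxicity in this test and higher numbers for lower toxicity in this test), compound 1 (`COc1ccc(CNC(=O)c2c([N+](=O)[O-])noc2-c2ccc([N+](=O)[O-])cc2)cc1OC`) stands at "not determined" (no result reported) for now. Compound 2 (`COc1ccc(CNC(=O)c2c([N+](=O)[O-])noc2-c2ccc(Cl)cc2)cc1OC`) gives 106000 nM and compound 3 (`O=C(NCc1cccc(Cl)c1Cl)c1c([N+](=O)[O-])noc1-c1ccc(Cl)cc1Cl`) gives 81800 nM in the same test. These two numbers lie within the scatter of each other, so compound 3 stands level with compound 2. Compound 4 (`COc1ccc(CNC(=O)c2c([N+](=O)[O-])noc2-c2ccc(Cl)cc2Cl)cc1OC`) is unmeasured. Its difference from compound 3 is 3,4-dimethoxyphenyl in place of 2,3-dichlorophenyl on a saturated chain carbon bound to an amide-type nitrogen and amounts to 3,4-dimethoxyphenyl in place of 2,3-dichlorophenyl on a saturated chain carbon bound to an amide-type nitrogen. Compound 2 also carries 3,4-dimethoxyphenyl and gives 106000 nM in this assay so no step beyond the scatter is expected. The expected change is a 1.2-fold higher number from compound 3 to compound 4 (0.09 log units; within the scatter) and stays within the scatter. For compound 4 the estimate is 100000 nM with an expected range from 45000 nM to 220000 nM in this test.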

Compound 4, half-maximal cytotoxic concentration: 81800 nM
Compound 4: middle estimate off by 1.2-fold (0.09 log units), on the high side; the range from low to high includes it.
By their numbers in this assay, from the lowest: compounds 3, 4 and 2 (each within the scatter of the next).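

In this assay, going by these compounds alone, the change to 3,4-dimethoxyphenyl in place of 2,3-dichlorophenyl on a saturated chain carbon bound to an amide-type nitrogen gives no change at the digits printed from compound 3 to compound 4 (within the scatter) and so offers the first direct reading at this position: both groups stand level here. Chloro in place of hydrogen on an aromatic carbon gives a 1.3-fold lower number from compound 2 to compound 4 (0.11 log units; within the scatter) and adds a second single-place step within the scatter. No measured property bears on these two results.

The compounds shown leave open whether an amine or a carboxylic acid on this saturated chain carbon would give a step beyond the scatter.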